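A few compounds are considered here, and "the series" means these few. Any claim that something is new, unique, unknown or untested is made for them only; others in the source may bear on it.

Compound 1 `COc1ccc(CNc2nc3cc(N)cc(N)c3nc2-c2ccccc2)cc1OC` is measured in a functional assay on HOP-92 cells (Homo sapiens) for inhibition, read by sulforhodamine B assay, with a stated time of 48 h (on this read-out lower numbers stand for higher toxicity in this test and higher numbers for lower toxicity in this test), and gives 66100 nM. Compound 2 `Nc1cc(N)c2nc(-c3ccccc3)c(NCc3ccc(F)cc3)nc2c1` is the partner that differs from it in one place. For compound 2 this assay reports only a limit, < 100000 nM, not a number. For the measured compounds named here, the one measured step, a step that the limit leaves unreadable from compound 1 to compound 2, therefore cannot be read for its size, and the only evidence on it is the limit of < 100000 nM in this assay, at which 1 of the 2 values shown sits. Compound 2 thus stands at the edge of the measured range, with no figure of its own.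

Compound 3 `Nc1cc(N)c2nc(-c3ccccc3)c(Sc3ccc(F)cc3)nc2c1` is the next, unmeasured member of the set. Its change from compound 2 is (4-fluorophenyl)sulfanyl in place of (4-fluorobenzyl)amino on an aromatic carbon. Going by the values given here, no measured step in this assay speaks for or against this kind of exchange, and the one step that exists is unreadable, so nothing beyond the scatter is expected in either direction. The step from compound 2 to compound 3 is estimated as a step that the limit leaves unreadable from compound 2 to compound 3. Compound 3 is therefore expected to give about 50000 nM, with a range from 15000 nM to 150000 nM.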

Compound 3, concentration lethal to 50% of the cells: < 100000 nM
Compound 3: only a limit was reported (the forecaster's own chance of this, stated with the estimate: 35%); the middle value does not contradict the limit.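

Compound 3 is also reported only as a limit, < 100000 nM, so no new step can be read between compound 2 and compound 3 in this assay. Whether the exchange of (4-fluorobenzyl)amino for (4-fluorophenyl)sulfanyl alters toxicity at all, and in which direction, stays open: the limit of < 100000 nM in this assay, at which 2 of the 3 values shown sit.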